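A few compounds are considered here, and "the series" means these few. Any claim that something is new, unique, unknown or untested is made for them only; others in the source may bear on it.

Measured so far in an ADME assay on L02 cells (Homo sapiens) for cytotoxicity, read by MTT assay, with a stated time of 48 h; a lower number here means a stronger inhibitor, a higher number a weaker inhibitor:

compound 1 `CCN1CCN(C[C@H]2CN(c3ccc(-n4cc(-c5ccccn5)cn4)c(F)c3)C(=O)O2)CC1`: 99 ug/mL
compound 2 `O=C1O[C@@H](CN2CCCCC2)CN1c1ccc(-n2cc(-c3ccccn3)cn2)c(F)c1`: > 400 ug/mL
compound 3 `O=C1O[C@@H](Cn2ccnn2)CN1c1ccc(-n2cc(-c3ccccn3)cn2)c(F)c1`: 49 ug/mL

Compound 1 holds the highest of the two plain numbers in this assay; its nearest neighbour is compound 3, which gives 49 ug/mL after a 2.0-fold lower number from compound 1 to compound 3 (0.31 log units; beyond the scatter). For compound 2 only a limit is reported, (the limit of > 400 ug/mL in this assay, at which 1 of the 3 values shown sits), so it stands apart from the numbers rather than above them.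

Compound 4 `CS(=O)(=O)NC[C@H]1CN(c2ccc(-n3cc(-c4ccccn4)cn3)c(F)c2)C(=O)O1` differs from compound 1 in one place: methanesulfonamido in place of 4-ethylpiperazin-1-yl on a saturated chain carbon bound to a saturated ring carbon. Among the measured compounds shown here, two measured steps bear on this position, both exchanging the same 4-ethylpiperazin-1-yl group of compound 1. Going to piperidin-1-yl gave an at least 4.0-fold higher number from compound 1 to compound 2 (0.60 log units; beyond the scatter), while going to 1H-1,2,3-triazol-1-yl gave a 2.0-fold lower number from compound 1 to compound 3 (0.31 log units; beyond the scatter). The two replacements therefore pulled in opposite directions, and neither is methanesulfonamido, so the direction for compound 4 is not fixed by what is known. The sensible expectation is a step that stays near compound 1, with no clear movement beyond the scatter, and with real chance of either a higher or a lower number.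

Compound 4 is accordingly estimated at 110 ug/mL in this assay, with a range of 45 ug/mL to 300 ug/mL. That estimate corresponds to an expected step of a 1.1-fold higher number from compound 1 to compound 4 (0.05 log units; within the scatter).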

Compound 4, half-maximal inhibitory concentration: > 400 ug/mL
Compound 4: only a limit was reported; the forecaster's own chance of this, stated with the estimate: 15%; middle value at least 3.6-fold (0.56 log units) from the limit.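

In this assay, methanesulfonamido moves the number the same way piperidin-1-yl did, with an at least 4.0-fold higher number from compound 1 to compound 4 (0.60 log units; beyond the scatter), so the upward step on a saturated chain carbon bound to a saturated ring carbon no longer rests on a single replacement, and it now also appears with a group that has no ring and carries a hydrogen-bond donor. Replacing 1H-1,2,3-triazol-1-yl with methanesulfonamido gives an at least 8.1-fold higher number from compound 3 to compound 4 (0.91 log units; beyond the scatter), which leaves 1H-1,2,3-triazol-1-yl as the only replacement of 4-ethylpiperazin-1-yl shown here that lowers the number. Compound 2 and compound 4 both carry only a limit, so the step between them cannot be read: the limit of > 400 ug/mL in this assay, at which 2 of the 4 values shown sit.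

Going by these compounds, it remains open whether the lower number belongs to 1H-1,2,3-triazol-1-yl alone or would also appear with another ring bound through nitrogen, such as imidazol-1-yl. A primary amine or a carboxylic acid at the same place would show whether compound 1 and compound 3 are exceptions in this series or whether the two limits are.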